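The source may report more compounds than this note shows. Statements on the series, on what has been measured and on what is new or still open speak of the compounds shown alone.

Measured in a physicochemical assay for solubility, using the shake flask method, in simulated intestinal fluid, measured as kinetic solubility, with a stated time of 2 h, at 25 degrees C, at pH 6.5; on this read-out lower numbers stand for lower solubility and higher numbers for higher solubility:
- Compound 1 `Cc1noc(-c2nc(C)c3c(c2N)C(=O)N(Cc2ccc(Oc4ccc(F)cc4)cc2)C3=O)n1`: 23800 nM
- Compound 2 `Cc1noc(-c2nc(C)c3c(c2N)C(=O)N(Cc2ccc(C(F)(F)F)cc2)C3=O)n1`: < 5000 nM (a limit)

Compound 2 stands at < 5000 nM, which is a limit of the assay and not a number. Compound 3 `Cc1noc(-c2nc(C)c3c(c2N)C(=O)N(Cc2ccc(Br)cc2)C3=O)n1` has bromo in place of trifluoromethyl on an aromatic carbon. Among the measured compounds shown here, one measured step bears on this position, an at least 4.7-fold lower number from compound 1 to compound 2 (0.67 log units; beyond the scatter), but it is a different exchange and ends in a limit. No step beyond the scatter is therefore expected in this assay, in either direction. The expected step is a step that the limit leaves unreadable from compound 2 to compound 3. Compound 3 is estimated at 4000 nM, with an expected range of 1500 nM to 10000 nM.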

Compound 3, solubility: < 5000 nM
Compound 3: a limit, no number; the forecaster's own chance of this, stated with the estimate: 65%; the middle value lies beyond the limit too.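

In this assay compound 3 gives < 5000 nM, which is a limit of the assay and not a number. Bromo in place of 4-fluorophenoxy on this aromatic carbon brings an at least 4.7-fold lower number from compound 1 to compound 3 (0.67 log units; beyond the scatter), so the drop seen with trifluoromethyl is not confined to that one group. The step from compound 2 to compound 3 cannot be read because both end at a limit: the limit of < 5000 nM in this assay, at which 2 of the 3 values shown sit.

From the compounds shown here alone, what numbers lie behind the two limits stays open. Also open, going by these compounds, is whether an amine, a carboxylic acid or a longer chain at this position would give a reading above the limit.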